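This account rests on a few compounds, and the source may have more. Where it says the series, first, only, none or still open, it means among the compounds named here.

Compound 3 `COc1ccc(/C=C\c2cc(OC)c(OC)c(OC)c2)cc1OCc1ccc(CN2CCCCC2C(=O)NCCN)cc1` stands at a limit: in a functional assay on MC-38 cells (Mus musculus) for antiproliferative activity, read by CCK-8 assay, with a stated time of 48 h (a higher number here means a weaker inhibitor, a lower number a stronger inhibitor), compound 3 gives > 10000 nM, which is a limit of the assay and not a number. Compound 1 `COc1ccc(/C=C\c2cc(OC)c(OC)c(OC)c2)cc1OCc1ccc(CN[C@H](C(=O)O)[C@H](C)O)cc1` also reaches only a limit, > 10000 nM. Compound 2 `COc1ccc(/C=C\c2cc(OC)c(OC)c(OC)c2)cc1OCc1ccc(CN2CCCC[C@H]2C(=O)O)cc1` likewise gives a limit, > 10000 nM. The three steps among these compounds, a step that the two limits leave unreadable from compound 1 to compound 2, a step that the two limits leave unreadable from compound 1 to compound 3 and a step that the two limits leave unreadable from compound 2 to compound 3, cannot be read, since every value sits at the limit of > 10000 nM in this assay, at which 3 of the 3 values shown sit. Compound 4 `COc1ccc(/C=C\c2cc(OC)c(OC)c(OC)c2)cc1OCc1ccc(CNCCNC(C)=O)cc1` differs from compound 3 by (2-acetamidoethyl)amino in place of 2-((2-aminoethyl)carbamoyl)piperidin-1-yl on a saturated chain carbon bound to an aromatic carbon. Going by the values given here, no measured step bears on this change in a readable way, so no size of step and no direction can be drawn from them. Compound 4 is expected to give about 15000 nM, most likely again a limit, with a range from 5000 nM to 50000 nM. The step from compound 3 to compound 4 is estimated at a step that the limit leaves unreadable from compound 3 to compound 4.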

Compound 4, half-maximal inhibitory concentration: 1800 nM
For compound 4 the middle estimate is 8.3-fold (0.92 log units) above the measured one; the whole stated range lies above it.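

In this assay there is an at least 5.5-fold lower number from compound 3 to compound 4 (0.74 log units; beyond the scatter) and an at least 5.5-fold lower number from compound 2 to compound 4 (0.74 log units; beyond the scatter) as well as an at least 5.5-fold lower number from compound 1 to compound 4 (0.74 log units; beyond the scatter) when (2-acetamidoethyl)amino stands on the saturated chain carbon bound to an aromatic carbon. This shows that a change at this place can bring real activity to the shared core. Going by these compounds, the true size of these steps stays unknown, since compounds 1, 2 and 3 reach only a limit of the assay and not a number: the limit of > 10000 nM in this assay, at which 3 of the 4 values shown sit.

Still open, on these data alone, is whether the acetamide itself matters, or whether a plain primary amine on the same chain would serve as well. As far as these compounds go, the effect of a longer chain between the two nitrogens also remains unknown.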